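Growing the Amide Substituent of Compound 3

A few compounds are considered here, and "the series" means these few. Any claim that something is new, unique, unknown or untested is made for them only; others in the source may bear on it.

Measured so far:
compound 1, `CN(C)S(=O)(=O)c1ccccc1Nc1cc(-c2ccc3ccn(C)c3c2)c2nccnc2c1`, gives 94 nM in an assay for inhibition of 6-phosphofructo-2-kinase/fructose-2,6-bisphosphatase 3 (Homo sapiens), read by ADP-Glo, with a stated time of 2 h; a lower number here means a stronger inhibitor, a higher number a weaker inhibitor
compound 2, `Cn1ccc2ccc(-c3cc(Nc4ccccc4S(=O)(=O)Nc4cncnc4)cc4nccnc34)cc21`, gives 1690 nM in this assay
compound 3, `CNC(=O)c1ccncc1Nc1cc(-c2ccc3ccn(C)c3c2)c2nccnc2c1`, gives 83 nM in this assay

Compound 3 shows the lowest of the three numbers, but its gap to compound 1 is within the usual scatter, so the two cannot be ranked against each other; only compound 2 stands clearly apart. Among the compounds with values here, the single measured step, an 18-fold higher number from compound 1 to compound 2 (1.25 log units; beyond the scatter), concerns the sulfonyl end of compound 1 and shows a large loss in this assay when that side group is exchanged.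

Compound 4, `CC(=O)N1CC(CNC(=O)c2ccncc2Nc2cc(-c3ccc4ccn(C)c4c3)c3nccnc3c2)C1`, differs from compound 3 in one place: 1-acetylazetidin-3-yl in place of hydrogen on a saturated chain carbon bound to an amide-type nitrogen. Within the data shown here, no measured pair alters the methylcarbamoyl handle of compound 3, so that one step bears on the new change only loosely, as a sign that this series can react strongly to a changed side group. Among the measured compounds shown here, with no direct precedent, the step of a 1.9-fold higher number from compound 3 to compound 4 (0.29 log units; within the scatter) is expected to be modest and to lean toward a weaker inhibitor. Compound 4 is therefore estimated at 160 nM in this assay, with a range from 50 nM to 500 nM.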

Compound 4, half-maximal inhibitory concentration: 137 nM
The estimate for compound 4 lay 1.2-fold (0.07 log units) above the measured number; the range from low to high includes it.
By their numbers in this assay, from the lowest: compounds 3, 1 and 4 (each within the scatter of the next); then compound 2.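

Placing 1-acetylazetidin-3-yl in place of hydrogen on a saturated chain carbon bound to an amide-type nitrogen gives, in this assay, a 1.7-fold higher number from compound 3 to compound 4 (0.22 log units; within the scatter), so compound 3 and compound 4 cannot be ranked against each other. Within the data shown here, this is the first view of the methylcarbamoyl end of compound 3: a group of 7 heavy atoms, with a four-membered ring and an acetyl carbonyl, enters there without a difference that can be told from the scatter, whereas the exchange at the sulfonyl end gave an 18-fold higher number from compound 1 to compound 2 (1.25 log units; beyond the scatter). Nothing available explains why the number holds so steady at this position, so the result stands as an observation only.

As far as these compounds go, it remains open whether this tolerance extends to other groups at the same place, such as a free azetidine without the acetyl, a primary amine, a carboxylic acid or a longer chain. One step also cannot show whether a larger or differently shaped ring here would move the number beyond the scatter in this assay.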